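A selenium-to-sulfur pair with a shared chain change

This account rests on a few compounds, and the source may have more. Where it says the series, first, only, none or still open, it means among the compounds named here.

Compound 1 `CCCCC/C=C\C/C=C\CCCCCCCC[Se]CCC(=O)NCc1ccc(O)c(OC)c1` and compound 2 `CCCCCCCC/C=C\CCCCCCCC[Se]CCC(=O)NCc1ccc(O)c(OC)c1` share a core and differ only by hept-1-en-1-yl in place of heptyl on a saturated chain carbon bound to a double-bonded chain carbon. In an assay on HEK293 cells for antagonist activity at transient receptor potential cation channel subfamily V member 2 (Rattus norvegicus), read by fluorescence and calcium flux, with a stated time of 5 min (on this read-out higher numbers stand for weaker inhibition and lower numbers for stronger inhibition), compound 1 gives 2300 nM, and in the same assay compound 2 gives 3200 nM; the step of a 1.4-fold lower number from compound 2 to compound 1 (0.14 log units; within the scatter) is within the scatter. Compound 3 `CCCCCCCC/C=C\CCCCCCCCSCCC(=O)NCc1ccc(O)c(OC)c1` gives "not determined" (no result reported) in this assay, and the difference between its core and that of compound 2 is not broken down here. Compound 4 `CCCCC/C=C\C/C=C\CCCCCCCCSCCC(=O)NCc1ccc(O)c(OC)c1` differs from compound 3 by hept-1-en-1-yl in place of heptyl on a saturated chain carbon bound to a double-bonded chain carbon, the same change seen between compound 2 and compound 1. Because compound 1 gives 2300 nM and the step of a 1.4-fold lower number from compound 2 to compound 1 (0.14 log units; within the scatter) is within the scatter, while compound 3 has no number, compound 4 is estimated at 2500 nM, expected between 700 nM and 9000 nM.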

Compound 4, half-maximal inhibitory concentration: 2800 nM
Estimate against measurement, compound 4: 1.1-fold (0.05 log units) below, within the range that was stated.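

For the compounds shown here, compound 3 carries no number, so no step from it to compound 4 can be read. The compounds shown leave open what hept-1-en-1-yl in place of heptyl does on the sulfur-containing chain. No supporting evidence bears on this result.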